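This account rests on a few compounds, and the source may have more. Where it says the series, first, only, none or still open, it means among the compounds named here.

Compound 1 `N#Cc1ccc(OCCCCCn2ccc(=O)[nH]c2=O)cc1` gives 100000 nM in an ADME assay on HEL cells (Homo sapiens) for cytotoxicity, read by microscopy (on this read-out lower numbers stand for higher toxicity in this test and higher numbers for lower toxicity in this test), the highest of the two numbers recorded there. Its nearest neighbour is compound 2 `O=c1ccn(CCCCCCOc2ccc(Br)cc2)c(=O)[nH]1`, which gives 20000 nM in this assay, a gap beyond the usual scatter. Compound 3 `O=c1ccn(CCCCCCCCOc2ccc(Br)cc2)c(=O)[nH]1` reaches only the limit of >= 100000 nM in this assay, so no number is known for it; this is the case noted in the limit of >= 100000 nM in this assay, at which 1 of the 3 values shown sits. Compound 4 `O=c1ccn(CCCCCOc2ccc(-c3ccccc3)cc2)c(=O)[nH]1` is not yet measured. It differs from compound 1 by phenyl in place of cyano on an aromatic carbon. Within the data shown here, no measured pair shows this kind of change, so the expected step from compound 1 to compound 4 rests on the structural change alone: compound 4 is expected to give 50000 nM, between 10000 nM and 100000 nM, a step of a 2.0-fold lower number from compound 1 to compound 4 (0.30 log units; within the scatter) that may not exceed the scatter.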

Compound 4, minimum cytotoxic concentration: 100000 nM
For compound 4 the middle estimate is 2.0-fold (0.30 log units) below the measured one, within the range that was stated.
By their numbers in this assay, from the lowest: compound 2; then compounds 1 and 4 (each within the scatter of the next).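

In this assay, phenyl in place of cyano on an aromatic carbon, para to a large group, shows no change at the digits printed from compound 1 to compound 4 (within the scatter). Among these compounds, this position therefore takes one six-membered aromatic ring of carbon only in place of the nitrile without a change beyond the scatter, and this is the first step between compounds differing in one place. Compound 3 gives a limit and not a number: the limit of >= 100000 nM in this assay, at which 1 of the 4 values shown sits.

From the compounds shown here alone, whether an amine or a carboxylic acid at this position would behave the same remains open. So does whether phenyl would give the same result on a longer chain.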